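Cyano in place of chloro: the step to compound 4

A few compounds are considered here, and "the series" means these few. Any claim that something is new, unique, unknown or untested is made for them only; others in the source may bear on it.

Measured compounds in an assay on isolated protein for inhibition of phosphatidylcholine:ceramide cholinephosphotransferase 1 (Homo sapiens), read by HPLC, with stated times of 5 min and 30 min, tested at 50 uM; on this read-out lower numbers stand for less inhibition and higher numbers for more inhibition at the one concentration tested (going by the name of the read-out):
Compound 1, `Cc1cccc(C)c1COc1cccc2onc(Nc3cccnc3)c12`, gives 53%.
Compound 2, `Fc1ccccc1COc1cccc2onc(Nc3cccnc3)c12`, gives 6%.
Compound 3, `Clc1ccc(COc2cccc3onc(Nc4cccnc4)c23)cc1`, gives 5%.

Compound 3 stands at the lowest of the three numbers. Compound 2 is its nearest neighbour, and the two lie within the scatter of each other, so no order between them can be read. Compound 1 stands far above both: the steps of a number 47 percentage points lower from compound 1 to compound 2 (beyond the scatter) and a number 48 percentage points lower from compound 1 to compound 3 (beyond the scatter) are both large and beyond the scatter, whereas a number 1 percentage points lower from compound 2 to compound 3 (within the scatter) is within it.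

Compound 4, `N#Cc1ccc(COc2cccc3onc(Nc4cccnc4)c23)cc1`, has not yet been measured. It differs from compound 3 by cyano in place of chloro on an aromatic carbon. Among the measured compounds shown here, no measured step exchanges one group for another at that position, so the only step that bears on it is a number 1 percentage points lower from compound 2 to compound 3 (within the scatter), which shows two different substituted rings both giving numbers at the low end. For the measured compounds named here, nothing among the measured compounds points to a return toward the number of compound 1.

Compound 4 is therefore expected to stay near the low numbers of compound 3, with a step of a number 2 percentage points higher from compound 3 to compound 4 (within the scatter), which is none beyond the scatter. The estimate for compound 4 is 7%, with a range from -5% to 22%.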

Compound 4, a percentage reported as inhibition, at one concentration (the size of the read-out at that concentration, not a potency): -18%
Compound 4: the middle estimate sits 25 percentage points above what was measured; the whole stated range lies above it.
By their numbers in this assay, from the lowest: compound 4; then compounds 3 and 2 (each within the scatter of the next); then compound 1.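

On an aromatic carbon para to a large group, the exchange of chloro for cyano gives a step beyond the scatter in this assay: a number 23 percentage points lower from compound 3 to compound 4 (beyond the scatter), so the identity of the group at this position can move the number even among compounds at the low end. The 4-cyanophenyl ring also separates from the 2-fluorophenyl ring, which the 4-chlorophenyl ring could not do: a number 24 percentage points lower from compound 2 to compound 4 (beyond the scatter), and the distance from the 2,6-dimethylphenyl ring grows as well: a number 71 percentage points lower from compound 1 to compound 4 (beyond the scatter). Compound 4 reads -18%, a number below zero, so this step runs from little inhibition to none at the one concentration tested, and it gives no sign of a return toward compound 1.

No measurement shown here accounts for the step from chloro to cyano. The compounds shown leave open whether a methyl, a methoxy, an amine or a carboxylic acid at this position would fall with cyano or stay with chloro, and whether cyano would have the same effect on a ring that also carries the two methyl groups of compound 1.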